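The compounds below may be only part of what the source reports. "The series", "measured", "known", "first", "only" and "open" are said of these compounds alone.

Measured so far in a functional assay on MCF7 cells (Homo sapiens) for cytotoxicity, read by MTT assay, with a stated time of 2 days, tested at 0.1 uM; a higher number here means a weaker effect of the compound at the concentration tested, a lower number a stronger effect:
compound 1 `CC(=O)c1cc(-c2ccc(F)cc2)cc2cc(-c3ccccc3)[nH]c12` gives 98.3%
compound 2 `CC(=O)c1cc(-c2ccccc2)cc2cc(-c3ccc(F)cc3)[nH]c12` gives 98.5%

Both numbers sit at the top of the scale for this assay, which means that at the concentration tested neither compound does much to the cells over the stated time. Compound 2 and compound 1 lie within the usual scatter of each other, so the two readings cannot be told apart, and neither compound can be called the weaker or the stronger of the pair.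

The next compound, compound 3 `CC(=O)c1cc(-c2ccc(F)cc2)cc2cc(-c3ccc(F)cc3)[nH]c12`, differs from compound 2 by a single change: fluoro in place of hydrogen on an aromatic carbon. Compound 1 and compound 2 each already carry one fluoro group on one of their two outer rings, and their values in this assay are indistinguishable. Nothing in the two numbers available points to a move of any size in either direction, and the expected step is therefore flat: from compound 2 to compound 3 the change a number 1 percentage points lower from compound 2 to compound 3 (within the scatter) is estimated to stay within the scatter. For compound 3 the expected value in this assay is 97.5%, with a range from 88% to 103%.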

Compound 3, a percentage reported as activity, at one concentration (the size of the read-out at that concentration, not a potency): 99.8%
Estimate against measurement, compound 3: 2.3 percentage points below, within the range that was stated.
By their numbers in this assay, from the lowest: compounds 1, 2 and 3 (each within the scatter of the next).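

In this assay the change from phenyl to 4-fluorophenyl can now be read at both outer rings of the shared core: at one ring the step is a number 1.3 percentage points higher from compound 2 to compound 3 (within the scatter) and at the other it is a number 1.5 percentage points higher from compound 1 to compound 3 (within the scatter). Neither step can be told from repeat scatter, so at this single concentration a second fluoro group gives no readable difference from one, whichever ring carried the first. No supporting data bear on this flat result.

From the compounds shown here alone, all three compounds carry only hydrogen or fluoro at these ring positions, so it remains open whether an amine, a carboxylic acid or a methoxy group on either outer ring would lower the number in this assay. The acetyl group is also common to all three, which leaves open what a longer chain or an amide in its place would do on the same core.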